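Methyl on the Sulfonyl Phenyl: Cytotoxicity Outlook for Compound 4

The compounds below may be only part of what the source reports. "The series", "measured", "known", "first", "only" and "open" are said of these compounds alone.

Compound 1 `CC(C)(C)c1ccc(N2CCN(Cc3ccc([N+](=O)[O-])o3)CC2)cc1`: > 63000 nM
Compound 2 `CC(C)(C)OC(=O)N1CCN(Cc2ccc([N+](=O)[O-])o2)CC1`: > 64000 nM
Compound 3 `O=[N+]([O-])c1ccc(CN2CCN(S(=O)(=O)c3ccccc3)CC2)o1`: > 56000 nM

In an ADME assay on HepG2 cells (Homo sapiens) for cytotoxicity, read by MTT assay, with a stated time of 24 h (on this read-out higher numbers stand for lower toxicity in this test and lower numbers for higher toxicity in this test), compound 1 gives > 63000 nM, a limit of the assay rather than a number. Compound 2 gives > 64000 nM, again a limit. Compound 3 gives > 56000 nM, also only a limit. Going by the values given here, all three values therefore stand at limits (the limit of > 56000 nM in this assay, at which 1 of the 3 values shown sits, (the limit of > 63000 nM in this assay, at which 1 of the 3 values shown sits), (the limit of > 64000 nM in this assay, at which 1 of the 3 values shown sits)), and no step between them can be sized. Compound 4 `Cc1ccc(S(=O)(=O)N2CCN(Cc3ccc([N+](=O)[O-])o3)CC2)cc1` differs from compound 3 by methyl in place of hydrogen on an aromatic carbon. With every measured value only a limit, no step beyond the usual scatter in this assay is expected for this change. Compound 4 is estimated to give 70000 nM, within 30000 nM to 160000 nM, most likely reported again as a limit. This expectation for compound 4 amounts to a step that the limit leaves unreadable from compound 3 to compound 4.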

Compound 4, half-maximal cytotoxic concentration: > 54000 nM
Compound 4: a limit, no number (the forecaster's own chance of this, stated with the estimate: 85%); the middle value lies beyond the limit too.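

Compound 3 gives > 56000 nM, a limit. Going by these compounds alone, compound 4 gives > 54000 nM, also a limit, so no step between the two can be read. The compounds shown leave open whether methyl in place of hydrogen changes cytotoxicity at all.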